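This account rests on a few compounds, and the source may have more. Where it says the series, first, only, none or still open, it means among the compounds named here.

Working notes on the series.

Within the data shown here, compound 1 `COc1cc(/C=C/C(=O)c2cccc(-n3cc(-c4ccc(Cl)cc4)[nH]c3=O)c2)ccc1O` and compound 2 `COc1cc(/C=C/C(=O)c2cccc(-n3cc(-c4ccccc4)[nH]c3=O)c2)cc(OC)c1OC` share a chalcone-type core and differ at several points at once, so no single step between them is counted. In a functional assay on A549 cells (Homo sapiens) for inhibition (on this read-out lower numbers stand for stronger inhibition of growth and higher numbers for weaker inhibition of growth), compound 1 gives 6780 nM. In this assay compound 2 gives 4030 nM. Of the two numbers shown, that of compound 1 is the higher, but the two values lie within the usual scatter of each other, so nothing can be read from the gap.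

Compound 3 `COc1cc(/C=C/C(=O)c2cccc(-n3cc(-c4ccccc4)[nH]c3=O)c2)ccc1O` is compound 1 with one change: hydrogen in place of chloro on an aromatic carbon. Among the measured compounds shown here, no measured pair shows this change on its own, so its effect is unknown here; the data only show that compound 2, which also carries a phenyl, gives 4030 nM.

For compound 3 the step of a 1.0-fold higher number from compound 1 to compound 3 (0.01 log units; within the scatter) is expected to be small, in either direction, and not clearly beyond the scatter. Compound 3 is thus estimated at 7000 nM, with a range from 3000 nM to 16000 nM.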

Compound 3, concentration for 50% growth inhibition: 3850 nM
For compound 3 the middle estimate is 1.8-fold (0.26 log units) above the measured one; the measured number falls inside the stated range.
By their numbers in this assay, from the lowest: compounds 3, 2 and 1 (each within the scatter of the next).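

The change from 4-chlorophenyl to phenyl can now be read on its own: in this assay, hydrogen in place of chloro on an aromatic carbon gives a 1.8-fold lower number from compound 1 to compound 3 (0.25 log units; within the scatter). For this one pair, chloro and hydrogen at this position, para to a large group, cannot be told apart on this read-out. No evidence bearing on this result is available.

Open, from the compounds shown here alone, is whether another group at this position, such as an amine or a carboxylic acid, would give a step beyond the scatter. Also open, going by these compounds, is whether chloro in place of hydrogen on the phenyl of compound 2 would give a step of similar size, since this single pair speaks only for the core of compound 1.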